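This account rests on a few compounds, and the source may have more. Where it says the series, first, only, none or still open, it means among the compounds named here.

Measured compounds:
Compound 1 `COc1cc(N)c(Cl)cc1C(=O)NC1CCNCC1` gives 398 nM in a functional assay on HEK293 cells for agonist activity at 5-hydroxytryptamine receptor 4 (Homo sapiens), read by cAMP accumulation; a lower number here means that less compound is needed, a higher number that more compound is needed for the effect.
Compound 2 `CCCCCN1CCC(NC(=O)c2cc(Cl)c(N)cc2OC)CC1` gives 25.1 nM in this assay.
Compound 3 `COc1cc(N)c(Cl)cc1C(=O)NC1CCN(CCCCCCCCO)CC1` gives 15.9 nM in this assay.

Compound 3 has the lowest number of the three in this assay; its nearest neighbour is compound 2, with the step of a 1.6-fold lower number from compound 2 to compound 3 (0.20 log units; within the scatter) within the scatter, and its furthest is compound 1, with a 25-fold lower number from compound 1 to compound 3 (1.40 log units; beyond the scatter).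

Compound 4 `COc1cc(N)c(Cl)cc1C(=O)NC1CCN(CCN2CCN(S(C)(=O)=O)CC2)CC1` has not yet been measured. Compared with compound 3 it carries 4-(methylsulfonyl)piperazin-1-yl in place of 6-hydroxyhexyl on a saturated chain carbon, two bonds along the chain from an amine nitrogen in a ring.

Going by the values given here, three measured steps bear on this. a 16-fold lower number from compound 1 to compound 2 (1.20 log units; beyond the scatter) and a 25-fold lower number from compound 1 to compound 3 (1.40 log units; beyond the scatter) show that putting a chain on the ring nitrogen brings a large gain, while a 1.6-fold lower number from compound 2 to compound 3 (0.20 log units; within the scatter) shows that lengthening that chain with a hydroxyl end changes little. Among the compounds with values here, compound 4 keeps a substituent on the ring nitrogen but exchanges the hydroxyalkyl tail for a ring-bearing group; no measured compound tests such a tail, so the expectation rests on the nitrogen substitution alone. Compound 4 is therefore expected to give a number close to that of compound 3, with a 1.9-fold higher number from compound 3 to compound 4 (0.28 log units; within the scatter), and its estimate is 30 nM, in the range 8 nM to 120 nM.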

Compound 4, half-maximal effective concentration: 20 nM
Compound 4: middle estimate off by 1.5-fold (0.18 log units), on the high side, within the range that was stated.
By their numbers in this assay, from the lowest: compounds 3, 4 and 2 (each within the scatter of the next); then compound 1.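

In this assay the chain on the ring nitrogen can carry 4-(methylsulfonyl)piperazin-1-yl in place of 6-hydroxyhexyl, at two bonds along the chain from that nitrogen, with a 1.3-fold higher number from compound 3 to compound 4 (0.10 log units; within the scatter) as the step. The same replacement of propyl gives a 1.3-fold lower number from compound 2 to compound 4 (0.10 log units; within the scatter) and so also stays within the scatter, which shows that this position accepts a six-membered non-aromatic ring with a sulfonyl-bearing end as readily as an open alkyl chain, and that the hydroxyl end of compound 3 is not needed to stay in this range. Nothing available explains why such different tails read alike.

Going by these compounds, it remains open whether the methylsulfonyl group contributes anything or an unsubstituted piperazine would serve as well. On these data alone, a chain ending in a carboxylic acid, a primary amine or a phenyl ring also remains untested here.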